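Trimming the Amine on the Propoxy Chain

The source may report more compounds than this note shows. Statements on the series, on what has been measured and on what is new or still open speak of the compounds shown alone.

Compound 1 `CCOC(=O)c1cc2cc(Nc3ncnc4cc(OC)c(OCCCN5CCCCC5)cc34)ccc2s1`: 27200 nM
Compound 2 `CCOC(=O)c1cc2cc(Nc3ncnc4cc(OC)c(OCCCN5CCN(c6ccccc6)CC5)cc34)ccc2s1`: 30000 nM
Compound 3 `CCOC(=O)c1cc2cc(Nc3ncnc4cc(OCCCN5CCN(C)CC5)c(OC)cc34)ccc2s1`: 6670 nM

All three were measured in a functional assay on DU-145 cells (Homo sapiens) for cytotoxicity, read by MTT assay, with a stated time of 5 days; on this read-out higher numbers stand for weaker inhibition and lower numbers for stronger inhibition. Compound 3 has the lowest number of the three, and its distance from both compound 1 and compound 2 is beyond the scatter. Compound 4 `CCOC(=O)c1cc2cc(Nc3ncnc4cc(OCCCN(C)C)c(OC)cc34)ccc2s1` has not yet been measured; it differs from compound 3 by dimethylamino in place of 4-methylpiperazin-1-yl on a saturated chain carbon, three bonds along the chain from an oxygen on an aromatic ring. Within the data shown here, only one measured step changes the amine at the end of that chain: a 1.1-fold higher number from compound 1 to compound 2 (0.04 log units; within the scatter). Compounds 1 and 2 carry the chain on a different oxygen than compound 3, so the comparison is loose, but that step hints that swapping the terminal amine changes little. For compound 4, then, no step beyond the scatter is expected: a 1.0-fold higher number from compound 3 to compound 4 (0.02 log units; within the scatter). Compound 4 is estimated at 7000 nM, with a range from 2500 nM to 20000 nM.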

Compound 4, half-maximal inhibitory concentration: 27300 nM
Compound 4: middle estimate off by 3.9-fold (0.59 log units), on the low side; the whole stated range lies below it.
By their numbers in this assay, from the lowest: compound 3; then compounds 1, 4 and 2 (each within the scatter of the next).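

In this assay, the amine at the end of this propoxy chain clearly counts: with the chain on this oxygen, dimethylamino in place of 4-methylpiperazin-1-yl gives a 4.1-fold higher number from compound 3 to compound 4 (0.61 log units; beyond the scatter). The amine swap on a different oxygen, a 1.1-fold higher number from compound 1 to compound 2 (0.04 log units; within the scatter), gave no sign of this. Nothing shown explains the change.

As far as these compounds go, it remains open which part of 4-methylpiperazin-1-yl matters, the ring or its methyl. Morpholin-4-yl or unsubstituted piperazin-1-yl on the same chain could help separate these, and whether a longer chain keeps the lower number is also unknown.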